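Plasma stability notes on a four-compound series

The source may hold more compounds than are shown below. What is called first, only, known or untested is meant among the compounds shown, and "the series" means these compounds.

Compound 1, `Cc1oc(=O)oc1COC(=O)N1C[C@@H]2C[C@H]1C(=O)Nc1cccc(c1)C(=O)OCc1oc(=O)oc1COC(=O)C1=C(S2)[C@H](C)[C@@H]2[C@@H]([C@@H](C)O)C(=O)N12`: 0%
Compound 2, `CCOC(=O)C1=C(S[C@H]2C[C@@H](C(=O)Nc3cccc(C(=O)OCC)c3)N(C(=O)OCc3oc(=O)oc3C)C2)[C@H](C)[C@@H]2[C@@H]([C@@H](C)O)C(=O)N12`: 9%
Compound 3, `CCOC(=O)C1=C(S[C@@H]2CN[C@H](C(=O)Nc3cccc(C(=O)OCC)c3)C2)[C@H](C)[C@@H]2[C@@H]([C@@H](C)O)C(=O)N12`: 5%

All three were read in an ADME assay on a cell-free system (plasma, Homo sapiens) for metabolic stability, read by LC-MS, with a stated time of 60 min, at 37 degrees C, tested at 50 uM; a higher number here means that more of the compound is left, a lower number that less of the compound is left. The three values lie within the usual scatter of one another, so no order among compounds 1, 2 and 3 is claimed.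

Compound 2 and compound 3 differ in one place: a hydrogen atom in place of a group of 11 heavy atoms (6 carbon, 5 oxygen; one five-membered aromatic ring with 2 hetero atoms), on an amine nitrogen in a ring. The step is a number 4 percentage points lower from compound 2 to compound 3 (within the scatter).

Compound 4, `C[C@@H](O)[C@H]1C(=O)N2C3=C(S[C@@H]4CN[C@@H](C4)C(=O)Nc4cccc(c4)C(=O)OCc4oc(=O)oc4COC3=O)[C@H](C)[C@H]12`, is not yet measured. It relates to compound 1 by the same kind of change: a hydrogen atom in place of a group of 11 heavy atoms (6 carbon, 5 oxygen; one five-membered aromatic ring with 2 hetero atoms), on an amine nitrogen in a ring. The place differs in its surroundings: in compound 1 the nitrogen sits in a five-membered non-aromatic ring that is part of a fused or bridged system of six rings, next to the ring atom that bears a fused ring, whereas in compound 2 it is next to the ring atom that bears a large group. The difference between the core of compound 1 and that of compound 2 is not broken down here.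

Because compound 1 gives 0% and the same kind of change gave a number 4 percentage points lower from compound 2 to compound 3 (within the scatter), a step of a number 3 percentage points higher from compound 1 to compound 4 (within the scatter) is expected for compound 4. Compound 4 is estimated at 3%, between 0% and 12%.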

Compound 4, percent of the compound remaining: 0%
For compound 4 the middle estimate is 3 percentage points above the measured one; low and high end bracket the measured number.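

In this assay, a hydrogen atom in place of the group of 11 heavy atoms on the amine nitrogen in the ring gives no change at the digits printed from compound 1 to compound 4 (within the scatter) on the core of compound 1. Set beside the earlier step, the same change reads alike on the two cores: the same change on two cores in this assay, a number 4 percentage points lower (within the scatter) from compound 2 to compound 3 and no change at the digits printed (within the scatter) from compound 1 to compound 4, 4 percentage points apart, within the scatter of two such steps

This agreement does not show that the change carries over in general, as all four compounds lie close to the bottom of the scale and compound 1 at 0% leaves no room for a lower number, so a real difference between the cores in that direction could not appear here.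

The compounds shown leave open how a carboxylic acid in place of the esters, or a simple acetyl group on the ring amine, would read in this assay. Also open, going by these compounds, is which bond breaks in each compound, as the read-out follows only the compound remaining.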